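Acetylated piperidine replaces methylpiperazinylethyl: clearance outlook

A few compounds are considered here, and "the series" means these few. Any claim that something is new, unique, unknown or untested is made for them only; others in the source may bear on it.

Measured compounds:
Compound 1 `C=CC(=O)Nc1cccc(-n2c(-c3nc(-c4cnn(C5CCN(C)CC5)c4)cnc3N)nc3ccccc32)c1`: 120 mL.min-1.g-1
Compound 2 `C=CC(=O)Nc1cccc(-n2c(-c3nc(-c4cnn(C5CCN(C)CC5)c4)cnc3N)nc3ccncc32)c1`: 68 mL.min-1.g-1
Compound 3 `C=CC(=O)Nc1cccc(-n2c(-c3nc(-c4cnn(CCN5CCN(C)CC5)c4)cnc3N)nc3ccccc32)c1`: 60 mL.min-1.g-1

In an ADME assay on liver for metabolic stability, with Liver microsome (Homo sapiens) as the target, using microsomes (on this read-out lower numbers stand for slow clearance and higher numbers for fast clearance), compound 3 gives 60 mL.min-1.g-1. Its gap to compound 2, which gives 68 mL.min-1.g-1 in this assay, is within the scatter, and so is its gap to compound 1, which gives 120 mL.min-1.g-1; the three numbers are therefore not separable on this read-out. For the measured compounds named here, the only single-point step among them, a 2.0-fold lower number from compound 1 to compound 3 (0.30 log units; within the scatter), is itself within the scatter.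

Compound 4 `C=CC(=O)Nc1cccc(-n2c(-c3nc(-c4cnn(C5CCN(C(C)=O)CC5)c4)cnc3N)nc3ccccc32)c1` is the next compound, not yet measured. It differs from compound 3 in one place: 1-acetylpiperidin-4-yl in place of 2-(4-methylpiperazin-1-yl)ethyl on an aromatic nitrogen. Going by the values given here, no measured step exchanges a group on this aromatic nitrogen for an acetylated one, so the change has no direct precedent here. Among the compounds with values here, the one comparison at the same position, a 2.0-fold lower number from compound 1 to compound 3 (0.30 log units; within the scatter), shows that swapping groups there moved the number by less than the scatter. Compound 4 is therefore expected to give 80 mL.min-1.g-1 in this assay, in a range from 35 mL.min-1.g-1 to 180 mL.min-1.g-1. This expectation corresponds to a 1.3-fold higher number from compound 3 to compound 4 (0.12 log units; within the scatter), a step judged not to exceed the scatter.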

Compound 4, intrinsic clearance in microsomes: > 300 mL.min-1.g-1
Compound 4 gave a limit, no number (the forecaster's own chance of this, stated with the estimate: 5%); middle value at least 3.7-fold (0.57 log units) away from the limit.
By their numbers in this assay, from the lowest: compounds 3, 2 and 1 (each within the scatter of the next). At a limit, above all of these: compound 4.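

In this assay, the group on this aromatic nitrogen proves able to move the read-out beyond the scatter: the earlier exchange there gave only a 2.0-fold lower number from compound 1 to compound 3 (0.30 log units; within the scatter), whereas 1-acetylpiperidin-4-yl in place of 2-(4-methylpiperazin-1-yl)ethyl gives an at least 5.0-fold higher number from compound 3 to compound 4 (0.69 log units; beyond the scatter). For the compounds shown here, the single exchange of acetyl in place of methyl on an amine nitrogen in a ring also gives an at least 2.5-fold higher number from compound 1 to compound 4 (0.39 log units; beyond the scatter), so the step is seen with either of the two measured neighbours as its starting point. Compound 4 stands at a limit of the assay, not at a number: the limit of > 300 mL.min-1.g-1 in this assay, at which 1 of the 4 values shown sits.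

As far as these compounds go, it remains open whether the acetyl group itself goes with the higher number, or whether any replacement of the methyl would; a free piperidine amine or a methanesulfonyl group on that nitrogen would separate the two. Also open, from the compounds shown here alone, is whether acetyl gives a similar step on the core of compound 2.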